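A few compounds are considered here, and "the series" means these few. Any claim that something is new, unique, unknown or untested is made for them only; others in the source may bear on it.

Working notes on the series, read in a functional assay on B16 cells (Mus musculus) for inhibition; a lower number here means a stronger inhibitor, a higher number a weaker inhibitor. Compound 1 (`CC(C)CN(CC(=O)N(CC(C)C)NC(=O)OCc1ccccc1)/N=C/c1ccccc1B(O)O`) gives 17300 nM and compound 2 (`CC(C)CN(CC(=O)N(Cc1ccccc1)NC(=O)OCc1ccccc1)/N=C/c1ccccc1B(O)O`) gives 25100 nM. Within the data shown here, compound 2 therefore stands level with the only other number available, within the scatter of it. Next is compound 3 (`CC(C)CN(CC(=O)N(Cc1ccccc1)NC(=O)OCc1ccccc1)/N=C/c1cccc(B(O)O)c1`), which has the same atoms as compound 2, joined differently: a group of 9 heavy atoms (6 carbon, 1 boron, 2 oxygen; one six-membered aromatic ring of carbon only) in place of a group of 9 heavy atoms (6 carbon, 1 boron, 2 oxygen; one six-membered aromatic ring of carbon only), on a carbon with a double bond to nitrogen. Among the measured compounds shown here, the one measured step, a 1.5-fold higher number from compound 1 to compound 2 (0.16 log units; within the scatter), lies within the scatter, but it sits elsewhere, on a saturated chain carbon bound to an amide-type nitrogen. For the measured compounds named here, no measured step tests a change on the carbon with a double bond to nitrogen, so the size of this step has no direct support. No shift beyond the scatter is expected, with a slight lean toward a higher number. The expected step is a 1.3-fold higher number from compound 2 to compound 3 (0.11 log units; within the scatter). For compound 3 the estimate is 32000 nM, with an expected range of 12000 nM to 80000 nM.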

Compound 3, half-maximal inhibitory concentration: 19900 nM
For compound 3 the middle estimate is 1.6-fold (0.21 log units) above the measured one; low and high end bracket the measured number.
By their numbers in this assay, from the lowest: compounds 1, 3 and 2 (each within the scatter of the next).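

In this assay, among these compounds, joining the same atoms differently on the carbon with a double bond to nitrogen gives a 1.3-fold lower number from compound 2 to compound 3 (0.10 log units; within the scatter) and thus provides the first measured step at this place, which the earlier step, a 1.5-fold higher number from compound 1 to compound 2 (0.16 log units; within the scatter) on a saturated chain carbon bound to an amide-type nitrogen, could not test. On the core of compound 2, this rearrangement of the group bearing the boronic acid therefore leaves the read-out within the scatter. No measurement is available to explain this result.

The compounds shown leave open whether the read-out at this place depends on the boronic acid itself, which a carboxylic acid on the same ring would test. They also leave open whether the same rearrangement would stay within the scatter on the core of compound 1, which carries the isopropyl group.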